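The source may report more compounds than this note shows. Statements on the series, on what has been measured and on what is new or still open speak of the compounds shown alone.

Measured compounds:
- Compound 1, `CCCn1c(=O)[nH]c2nc(-c3ccc(S(=O)(=O)N4CCN(c5cccc(Br)c5)CC4)cc3)[nH]c2c1=O`, 0.234 nM
- Compound 2, `CCCn1c(=O)[nH]c2nc(-c3ccc(S(=O)(=O)N4CCN(c5ccccc5)CC4)cc3)[nH]c2c1=O`, 0.643 nM

In an assay on CHO cells for displacement of a labelled ligand from adenosine receptor A2b (Homo sapiens), read by scintillation counting, with a stated time of 75 min, in the presence of a further agent that is not named here (a lower number here means a stronger inhibitor, a higher number a weaker inhibitor), compound 2 gives the higher of the two numbers shown, and its nearest neighbour is compound 1, a halogen-bearing analogue on the same core. For the measured compounds named here, the only measured step, a 2.7-fold higher number from compound 1 to compound 2 (0.44 log units; beyond the scatter), was hydrogen in place of bromo on an aromatic carbon, and removing the halogen raised the number. Compound 3, `CCCn1c(=O)[nH]c2nc(-c3ccc(S(=O)(=O)N4CCN(c5ccc(I)cc5)CC4)cc3)[nH]c2c1=O`, is reached from compound 2 by iodo in place of hydrogen on an aromatic carbon, that is, a halogen is put back onto the same six-membered ring, though at a different position and with iodine instead of bromine. On the strength of that single step, a lower number is expected for compound 3, in the opposite direction and of similar size, so the estimate is a 2.6-fold lower number from compound 2 to compound 3 (0.41 log units; beyond the scatter). Compound 3 is therefore expected to give about 0.25 nM in this assay, within a range from 0.1 nM to 0.7 nM.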

Compound 3, inhibition constant: 0.159 nM
Beside the measured number, compound 3's estimate is 1.6-fold (0.20 log units) above it; measured number inside the range.
By their numbers in this assay, from the lowest: compounds 3 and 1 (each within the scatter of the next); then compound 2.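

In this assay the iodo group on the phenyl ring, para to a large group, also goes with a lower number (a 4.0-fold lower number from compound 2 to compound 3 (0.61 log units; beyond the scatter)), so the earlier drop seen with bromo is not confined to one ring position or one halogen, and neither halogen-bearing compound goes against this. The two halogen-bearing compounds cannot be told apart (a 1.5-fold lower number from compound 1 to compound 3 (0.17 log units; within the scatter)), even though they differ in both the halogen and its position. Nothing given here explains the lower number with either halogen.

Going by these compounds, because the halogen and its position change together between compound 1 and compound 3, the separate contribution of each stays open. The compounds shown also leave open what fluoro, chloro, methoxy or an amine on this ring would do to the number.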